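Fluorophenyl amide series: the step from compound 3 to compound 4

The source may report more compounds than this note shows. Statements on the series, on what has been measured and on what is new or still open speak of the compounds shown alone.

Measured in an assay on MDA-MB-231 cells for binding affinity to C-X-C chemokine receptor type 4 (Homo sapiens), read by immunofluorescence and microscopy, with stated times of 10 min and 30 min; on this read-out lower numbers stand for an effect already at smaller amounts and higher numbers for an effect only at larger amounts of compound:
compound 1 `Cc1ccc(C(=O)NCc2ccc(CNS(=O)(=O)c3ccc(C)cc3)cc2)cc1` gives 1000 nM
compound 2 `Cc1ccc(S(=O)(=O)NCc2ccc(CNC(=O)c3ccccc3)cc2)cc1` gives only a limit, > 1000 nM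
compound 3 `Cc1ccc(S(=O)(=O)NCc2ccc(CNC(=O)c3ccccc3F)cc2)cc1` gives 1000 nM

Compound 3 stands level with compound 1, as shown by no change at the digits printed from compound 1 to compound 3 (within the scatter). Compound 2 sits at the limit (the limit of > 1000 nM in this assay, at which 1 of the 3 values shown sits), so a number no lower from compound 1 to compound 2 (the limit leaves the size open) and a number no higher from compound 2 to compound 3 (the limit leaves the size open) are open in size. Compound 4 `Cc1ccc(S(=O)(=O)NCc2ccc(CNC(=O)c3ccc(F)cc3)cc2)cc1` is the next member; its change from compound 3 is 4-fluorophenyl in place of 2-fluorophenyl on a carbonyl carbon. Within the data shown here, no measured step moves fluoro within the ring, but compound 1 with 4-methylphenyl and compound 3 with 2-fluorophenyl read the same, so compound 4 is expected to show no step beyond the scatter, no change at the digits printed from compound 3 to compound 4 (within the scatter). Compound 4 is thus estimated at 1000 nM, between 500 nM and 2000 nM, with some chance of a limit.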

Compound 4, effective concentration (reported as EC, without a stated level of effect): 1 nM
For compound 4 the middle estimate is 1000-fold (3.00 log units) above the measured one; measured number below the stated range.
By their numbers in this assay, from the lowest: compound 4; then compounds 1 and 3 (each within the scatter of the next).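

On the carbonyl carbon, 2-fluorophenyl and 4-fluorophenyl are not interchangeable, although they have the same atoms: in this assay there is a 1000-fold lower number from compound 3 to compound 4 (3.00 log units; beyond the scatter). With the group in the 4-fluorophenyl form, fluoro in place of methyl gives a 1000-fold lower number from compound 1 to compound 4 (3.00 log units; beyond the scatter), and fluoro in place of hydrogen gives an at least 1000-fold lower number from compound 2 to compound 4 (3.00 log units; beyond the scatter). Compound 2 gives a limit, not a number: the limit of > 1000 nM in this assay, at which 1 of the 4 values shown sits.

Going by these compounds, how 4-chlorophenyl or 4-methoxyphenyl would read in place of 4-fluorophenyl on the carbonyl carbon remains open. The values do not tell what underlies the large gap.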